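From bromo to cyclopentyl on the shared core

The source may report more compounds than this note shows. Statements on the series, on what has been measured and on what is new or still open speak of the compounds shown alone.

In a functional assay on HUVEC cells (Homo sapiens), read by scintillation counting and thymidine incorporation, with a stated time of 24 h (a higher number here means a weaker inhibitor, a lower number a stronger inhibitor), the measured compounds stand as follows:
- compound 1 `CCC(C)n1ncn(-c2ccc(N3CCN(c4ccc(OC[C@@H]5CO[C@@](CC)(c6ccc(Cl)cc6Cl)O5)cc4)CC3)cc2)c1=O` gives 353 nM
- compound 2 `CCC(C)n1ncn(-c2ccc(N3CCN(c4ccc(OC[C@@H]5CO[C@@](CBr)(c6ccc(Cl)cc6Cl)O5)cc4)CC3)cc2)c1=O` gives 569 nM

Going by the values given here, with only two numbers available, compound 2 has just one neighbour, and the values of compound 1 and compound 2 lie within the usual scatter of each other. The two cannot be told apart.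

Compound 3 `CCC(C)n1ncn(-c2ccc(N3CCN(c4ccc(OC[C@@H]5CO[C@@](CC6CCCC6)(c6ccc(Cl)cc6Cl)O5)cc4)CC3)cc2)c1=O` keeps the core of compound 2 and changes one group (cyclopentyl in place of bromo on a saturated chain carbon bound to a saturated ring carbon), with cyclopentyl in place of bromo on a saturated chain carbon bound to a saturated ring carbon.

Among the compounds with values here, only one measured step bears on this place: a 1.6-fold higher number from compound 1 to compound 2 (0.21 log units; within the scatter), which put bromo in place of methyl. Within the data shown here, it stays inside the scatter, but no measured compound carries a ring on that carbon, so it is a thin guide. No step beyond the scatter is expected in this assay, in either direction, though the uncertainty is wide. The expected change is a 1.1-fold higher number from compound 2 to compound 3 (0.02 log units; within the scatter) as an estimate. The estimated value for compound 3 is 600 nM, with an expected range from 220 nM to 1600 nM as its limits.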

Compound 3, half-maximal inhibitory concentration: 512 nM
Estimate against measurement, compound 3: 1.2-fold (0.07 log units) above; the measured number falls inside the stated range.
By their numbers in this assay, from the lowest: compounds 1, 3 and 2 (each within the scatter of the next).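

In this assay, cyclopentyl in place of bromo on a saturated chain carbon bound to a saturated ring carbon gives a 1.1-fold lower number from compound 2 to compound 3 (0.05 log units; within the scatter), and cyclopentyl in place of methyl at the same place gives a 1.5-fold higher number from compound 1 to compound 3 (0.16 log units; within the scatter). Until now, this place had shown only bromo and methyl; it now shows that even a change from bromo, with 1 heavy atom and no ring, to cyclopentyl, with 5 heavy atoms and a five-membered non-aromatic ring, stays within the usual scatter, leaving the three compounds impossible to tell apart. Nothing available gives a reason for this result.

Neither bromo nor cyclopentyl carries a hydrogen-bond donor, a hydrogen-bond acceptor or a net charge, and the compounds shown leave open how an amine or a carboxylic acid would behave at this place. On these data alone, a phenyl ring or a longer chain also remains open, as does whether any group here can produce a step beyond the scatter in this assay.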